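The compounds below may be only part of what the source reports. "The series", "measured", "known", "first", "only" and "open" are said of these compounds alone.

Compound 3 `CCCNC(=S)NS(=O)(=O)c1ccc(-n2nc(C)cc2C)cc1` stands at a limit in a functional assay on the whole organism (blood, strain albino) with Mus musculus as the target, with stated times of 6 days and 4 h, at a dose of 0.4 mmol/kg by the oral route; on this read-out lower numbers stand for less inhibition and higher numbers for more inhibition at the one dose given (going by the name of the read-out): compound 3 gives < 1%, a limit of the assay and not a number. Compound 2 `CCCNC(=S)NS(=O)(=O)c1ccc(-n2nc(C(=O)O)cc2C)cc1` likewise sits at a limit, giving < 1%. Compound 1 `Cc1cc(C)n(-c2ccc(S(=O)(=O)NC(=O)NNC(=N)N)cc2)n1` gives 3%. The step of a number at least 2 percentage points lower from compound 1 to compound 3 (that floor lies within the scatter) is the only readable one in the series; the step that the two limits leave unreadable from compound 2 to compound 3 cannot be sized because both ends sit at the limit of < 1% in this assay, at which 2 of the 3 values shown sit. Compound 4 `Cc1cc(C)n(-c2ccc(S(=O)(=O)NC(=S)Nc3ccccc3)cc2)n1` differs from compound 3 by phenyl in place of propyl on an amide-type nitrogen. For the measured compounds named here, no measured step touches this change, and all values shown stay low, two of them at a limit. Compound 4 is therefore expected to give 2%, between 0% and 10%. The step of a number at least 1 percentage points higher from compound 3 to compound 4 (that floor lies within the scatter) is thus expected to stay within the scatter, with a fair chance that only a limit is reported.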

Compound 4, a percentage reported as inhibition, in the whole organism at one dose (the size of the read-out at that dose, not a potency): -3%
The estimate for compound 4 lay 5 percentage points above the measured number; the whole stated range lies above it.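

In this assay no new step can be read from compound 3 to compound 4, because compound 3 stands at a limit: the limit of < 1% in this assay, at which 2 of the 4 values shown sit.

On these data alone, whether phenyl in place of propyl on the amide-type nitrogen changes this read-out at all stays open.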